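Compound 1 to compound 4: nitro replaced by trifluoromethyl

The source may hold more compounds than are shown below. What is called first, only, known or untested is meant among the compounds shown, and "the series" means these compounds.

The series is read in an ADME assay on HepG2 cells (Homo sapiens) for cytotoxicity, with a stated time of 72 h (on this read-out higher numbers stand for an effect only at larger amounts of compound and lower numbers for an effect already at smaller amounts), throughout. Compound 1 `Cc1cc(NC(=O)Nc2cccc([N+](=O)[O-])c2)c2ccccc2n1` gives > 25000 nM as a limit of the assay and not a number. Compound 2 `Cc1cc(NC(=O)Nc2cc(F)cc(F)c2)c2ccccc2n1` gives > 25000 nM as a limit as well. Going by the values given here, compound 3 `Cc1cc(NC(=O)Nc2ccc(C(F)(F)F)cc2)c2ccccc2n1` gives 23000 nM as the only numeric reading so far. Compound 1 thus stands at the limit of > 25000 nM in this assay, at which 2 of the 3 values shown sit, in this series.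

Compound 4 `Cc1cc(NC(=O)Nc2cccc(C(F)(F)F)c2)c2ccccc2n1` awaits measurement. It keeps the shared core of compound 1 and takes trifluoromethyl in place of nitro on an aromatic carbon, meta to a large group, counted as trifluoromethyl in place of nitro on an aromatic carbon for this change. Among the compounds with values here, no measured step sizes this change directly. Compound 3 also carries trifluoromethyl and reads 23000 nM in this assay so compound 4 is expected to sit close to compound 1 with no step beyond the scatter. The estimated change is an at least 1.0-fold lower number from compound 1 to compound 4 (0.03 log units; that floor lies within the scatter) and is expected to stay within that scatter. For compound 4 the expected value is 23000 nM with an estimated range from 13000 nM to 40000 nM and a reading that is only a limit remains possible.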

Compound 4, half-maximal effective concentration: 21000 nM
Beside the measured number, compound 4's estimate is 1.1-fold (0.04 log units) above it; the range from low to high includes it.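

In this assay, trifluoromethyl in place of nitro on an aromatic carbon, meta to a large group, gives an at least 1.1-fold lower number from compound 1 to compound 4 (0.07 log units; that floor lies within the scatter). Compound 1 gives > 25000 nM, a limit and not a number, so this first step at this position has only a floor and no full size: the limit of > 25000 nM in this assay, at which 2 of the 4 values shown sit. Compound 4 now gives a numeric reading at this position, 21000 nM, and compound 3, which also carries trifluoromethyl, gives 23000 nM.

Going by these compounds, the true distance between compound 1 and compound 4 stays open, as does whether any group on this aromatic carbon brings the reading to much smaller amounts of compound. An amine, a carboxylic acid or a longer chain at this position would put that question to the series.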